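Swapping a Bromophenyl for a Nonyl Chain

The source may hold more compounds than are shown below. What is called first, only, known or untested is meant among the compounds shown, and "the series" means these compounds.

Of the compounds shown here, two of a shared core have been measured in a functional assay on SK-N-SH cells (Homo sapiens) for inhibition, read by MTT assay; on this read-out lower numbers stand for stronger inhibition and higher numbers for weaker inhibition. Compound 1, with the structure `O=C(CN1CCC(Cc2ccccc2)CC1)Nc1ccc(C(=O)/C=C/c2cn(Cc3ccc(Br)cc3)nn2)cc1`, gives 42900 nM in this assay. Compound 2, with the structure `O=C(CBr)Nc1ccc(C(=O)/C=C/c2cn(Cc3ccc(Br)cc3)nn2)cc1`, gives 8300 nM, the lowest of the two numbers; the gap to compound 1 lies beyond the usual scatter of repeated measurements.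

Compound 3, with the structure `CCCCCCCCCCn1cc(/C=C/C(=O)c2ccc(NC(=O)CBr)cc2)nn1`, has not yet been measured. It differs from compound 2 in one place: nonyl in place of 4-bromophenyl on a saturated chain carbon bound to an aromatic nitrogen. Seen one bond further out, this is a 4-bromobenzyl group giving way to a decyl group.

Among the compounds with values here, with no measured pair showing what this exchange does, the expected step from compound 2 to compound 3 is a small one, a 1.7-fold lower number from compound 2 to compound 3 (0.22 log units; within the scatter), perhaps toward a lower number but possibly still within the scatter. Compound 3 is therefore estimated at 5000 nM in this assay, with a range from 1500 nM to 20000 nM.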

Compound 3, half-maximal inhibitory concentration: 8680 nM
For compound 3 the middle estimate is 1.7-fold (0.24 log units) below the measured one, within the range that was stated.
By their numbers in this assay, from the lowest: compounds 2 and 3 (each within the scatter of the next); then compound 1.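

In this assay, putting nonyl in place of 4-bromophenyl on a saturated chain carbon bound to an aromatic nitrogen gives a 1.0-fold higher number from compound 2 to compound 3 (0.02 log units; within the scatter), so this read-out does not separate compound 2 from compound 3. At this position, then, an open chain with no ring can stand in for a ring carrying bromine with no gain or loss that the assay can detect. Nothing available explains why the two compounds match.

From the compounds shown here alone, whether a chain carrying an amine or a carboxylic acid, or a chain longer than decyl, would fit this position equally well remains open. Going by these compounds, it is also open whether the same exchange would give a similar result on the core of compound 1.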